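The compounds below may be only part of what the source reports. "The series", "measured", "known", "first", "only" and "open" are said of these compounds alone.

In a functional assay on HepG2 cells (Homo sapiens) for inhibition, read by scintillation counting, with a stated time of 2 h (a lower number here means a stronger inhibitor, a higher number a weaker inhibitor), three compounds on a shared core have been examined so far. For compound 1 `CCCCC(=O)N1CCC(N2CCN(C(=O)c3c(NC(=O)NCC)sc4ccccc34)CC2)CC1` the entry reads "not determined" (no result reported), so it offers no number. Compound 2 `CCNC(=O)Nc1sc2ccccc2c1C(=O)N1CCN(C2CCN(C(=O)C3CCCC3)CC2)CC1` gives 309 nM and compound 3 `CCNC(=O)Nc1sc2ccccc2c1C(=O)N1CCN(C2CCN(C(=O)OC(C)C)CC2)CC1` gives 208 nM. Within the data shown here, these are the only two numbers, and they lie within the scatter of each other, so compound 3 cannot be separated from compound 2.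

Compound 4 `CCNC(=O)Nc1sc2ccccc2c1C(=O)N1CCN(C2CCN(C(=O)OC(C)(C)CF)CC2)CC1` is still unmeasured. It carries fluoromethyl in place of hydrogen on a saturated chain carbon bound to an oxygen next to a carbonyl group and two saturated chain carbons, turning isopropyl into 1-(fluoromethyl)-1-methylethyl: fluoromethyl in place of hydrogen on a saturated chain carbon bound to an oxygen next to a carbonyl group and two saturated chain carbons. Among the measured compounds shown here, the only guide is the measured step of a 1.5-fold lower number from compound 2 to compound 3 (0.17 log units; within the scatter), with isopropoxy in place of cyclopentyl on a carbonyl carbon. That is a different change, and it stayed within the scatter. No shift beyond the scatter is therefore expected, and the estimated step is a 1.0-fold lower number from compound 3 to compound 4 (0.02 log units; within the scatter). Compound 4 is estimated at 200 nM, with an expected range from 90 nM to 450 nM.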

Compound 4, half-maximal inhibitory concentration: 61 nM
Compound 4: the middle estimate sits 3.3-fold (0.52 log units) above what was measured; the measured number lies below the stated range.
By their numbers in this assay, from the lowest: compound 4; then compounds 3 and 2 (each within the scatter of the next).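

In this assay, among these compounds, this position on the saturated chain carbon bound to an oxygen proves responsive: turning isopropyl into 1-(fluoromethyl)-1-methylethyl gives a 3.4-fold lower number from compound 3 to compound 4 (0.53 log units; beyond the scatter) and is the first single change here to step beyond the scatter. Compound 4 also separates clearly from the cyclopentyl compound, with a 5.1-fold lower number from compound 2 to compound 4 (0.70 log units; beyond the scatter) even though the change from cyclopentyl to isopropoxy alone stayed within the scatter. No measurement available here accounts for this gain.

Going by these compounds, whether the step comes from the fluorine or from the added carbon stays open, and a tert-butyl group in the same place would separate the two. Difluoromethyl or trifluoromethyl in place of fluoromethyl would show whether the trend continues beyond this single example.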